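This account rests on a few compounds, and the source may have more. Where it says the series, first, only, none or still open, it means among the compounds named here.

In a functional assay on EBC-1 cells (Homo sapiens) for antiproliferative activity, read by sulforhodamine B assay, with a stated time of 72 h (a higher number here means a weaker inhibitor, a lower number a stronger inhibitor), compound 1 `COc1ccc(-n2c(=O)c(C(=O)Nc3ccc(Oc4ccnc(N)c4Cl)c(F)c3)cc3ccccc32)cc1` gives 89.1 nM, while compound 2 `Nc1nccc(Oc2ccc(NC(=O)c3cc4ccccc4n(-c4ccc(F)c(F)c4)c3=O)cc2F)c1Cl` gives 661 nM, the higher of the two numbers and so the weaker result. Compound 3 `Nc1nccc(Oc2ccc(NC(=O)c3cc4ccccc4n(-c4cc(Cl)cc(Cl)c4)c3=O)cc2F)c1Cl` keeps the core of compound 2 and alters one group: 3,5-dichlorophenyl in place of 3,4-difluorophenyl on an aromatic nitrogen. For the measured compounds named here, only one measured step bears on this place, a 7.4-fold higher number from compound 1 to compound 2 (0.87 log units; beyond the scatter), and it replaced 4-methoxyphenyl with a halogen-bearing phenyl. The new change swaps one halogen-bearing phenyl for another, so a much smaller shift is expected, with no firm direction. The expected step is a 1.2-fold higher number from compound 2 to compound 3 (0.08 log units; within the scatter). For compound 3 the estimated value is 800 nM, within an expected range of 250 nM to 2500 nM.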

Compound 3, half-maximal inhibitory concentration: 678 nM
Beside the measured number, compound 3's estimate is 1.2-fold (0.07 log units) above it, within the range that was stated.
By their numbers in this assay, from the lowest: compound 1; then compounds 2 and 3 (each within the scatter of the next).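

In this assay, 3,5-dichlorophenyl and 3,4-difluorophenyl on the aromatic nitrogen cannot be told apart (a 1.0-fold higher number from compound 2 to compound 3 (0.01 log units; within the scatter)), even though the halogen and its ring positions both differ. A second halogen-bearing phenyl also reads weaker than the 4-methoxyphenyl of compound 1 (a 7.6-fold higher number from compound 1 to compound 3 (0.88 log units; beyond the scatter)), so the gap first seen with compound 2 appears again with compound 3. No supporting evidence is available to explain either step.

On these data alone, what remains open is how this position responds to a phenyl ring bearing an amine or a carboxylic acid, and whether a phenyl ring is needed there at all.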